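Chain extension by one methyl: compound 2 to compound 3

The source may report more compounds than this note shows. Statements on the series, on what has been measured and on what is new or still open speak of the compounds shown alone.

Measured so far:
Compound 1, `CCCCCCCNC[C@@H]1OC[C@H](N)[C@H]1O`: in a functional assay on MCF7 cells (Homo sapiens) for antiproliferative activity, read by MTT assay, with a stated time of 72 h (a lower number here means a stronger inhibitor, a higher number a weaker inhibitor), compound 1 gives a limit of the assay, > 128000 nM.
Compound 2, `CCCCCCCCCCCNC[C@@H]1OC[C@H](N)[C@H]1O`: in this assay compound 2 gives 13100 nM.

For the measured compounds named here, compound 2 holds the only actual number; the value for compound 1 is a limit and not a number, which is the situation described by the limit of > 128000 nM in this assay, at which 1 of the 2 values shown sits. Going by the values given here, the one measured step, an at least 9.7-fold lower number from compound 1 to compound 2 (0.98 log units; beyond the scatter), is the whole of the evidence on chain length so far, and its size is bounded only on one side because compound 1 sits at a limit.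

Compound 3, `CCCCCCCCCCCCNC[C@@H]1OC[C@H](N)[C@H]1O`, is the next member. It differs from compound 2 by methyl in place of hydrogen on a saturated chain carbon, ten or more bonds along the chain from an amine nitrogen. This is the same kind of change as the measured step, cut to a single carbon rather than four, so a smaller step in the same direction is expected in this assay, possibly no larger than the scatter. Compound 3 is therefore estimated at 7500 nM, with a range from 2500 nM to 20000 nM, meaning an expected step of a 1.7-fold lower number from compound 2 to compound 3 (0.24 log units; within the scatter).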

Compound 3, half-maximal inhibitory concentration: 12600 nM
For compound 3 the middle estimate is 1.7-fold (0.23 log units) below the measured one; the measured number falls inside the stated range.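

In this assay, the added methyl on a saturated chain carbon gives a 1.0-fold lower number from compound 2 to compound 3 (0.02 log units; within the scatter), so compound 2 and compound 3 cannot be told apart on this read-out. For the compounds shown here, this is the first measured comparison between two chains that both give a number, and it shows that one further carbon at this place has no readable effect, whereas the longer extension still gives an at least 10-fold lower number from compound 1 to compound 3 (1.00 log units; beyond the scatter). Compound 1 gives a limit and not a number, so that longer step has a bound but no exact size: the limit of > 128000 nM in this assay, at which 1 of the 3 values shown sits.

The compounds shown leave open where along the chain the difference from compound 1 arises, and whether a longer chain than that of compound 3 would hold the same level or move away from it. They also leave open how this chain series would respond to a hydroxyl in place of the primary amine on the shared core, or to an amide in place of the amine nitrogen that carries the chain.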